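Replacing an Acyl Group by a Sulfonyl on the Shared Core

The source may report more compounds than this note shows. Statements on the series, on what has been measured and on what is new or still open speak of the compounds shown alone.

Of the compounds shown here, two on a shared core have been measured so far. In a functional assay on MDA-MB-231 cells (Homo sapiens) for inhibition, read by sulforhodamine B assay, tested at 10 uM (on this read-out higher numbers stand for more inhibition at the one concentration tested (going by the name of the read-out) and lower numbers for less inhibition), compound 1 `CN1CCN(c2ccc(C3=NN(C(=O)c4ccc(C(F)(F)F)cc4)C(c4ccc(N(C)C)cc4)C3)cc2)CC1` gives 55.4%. In this assay compound 2 `CN1CCN(c2ccc(C3=NN(C(=O)/C=C/c4ccccc4)C(c4ccc(N(C)C)cc4)C3)cc2)CC1` gives 35.9%. Among the measured compounds shown here, the one measured step is a number 19.5 percentage points lower from compound 1 to compound 2 (beyond the scatter), so compound 2 stands lowest of the two numbers, with compound 1 its only neighbour.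

Compound 3 `Cc1ccc(S(=O)(=O)N2N=C(c3ccc(N4CCN(C)CC4)cc3)CC2c2ccc(N(C)C)cc2)cc1` differs from compound 2 in one place: (4-methylphenyl)sulfonyl in place of (2-phenylethenyl)carbonyl on an amine nitrogen in a ring. For the measured compounds named here, the only measured step swaps one carbonyl-bearing group for another on the same ring nitrogen, so it bears on this change only loosely; no measured pair exchanges a carbonyl for a sulfonyl. The direction of the step is therefore open, and a change of roughly the size already seen, either way, is as likely as none. Compound 3 is expected to land near 45%, within 20% to 70%, which would mean an estimated step of a number 9.1 percentage points higher from compound 2 to compound 3 (within the scatter).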

Compound 3, a percentage reported as inhibition, at one concentration (the size of the read-out at that concentration, not a potency): 10.7%
Compound 3: middle estimate off by 34.3 percentage points, on the high side; the whole stated range lies above it.
By their numbers in this assay, from the lowest: compound 3; then compound 2; then compound 1.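

Among the compounds shown here, this is the first look at a sulfonyl on the ring nitrogen of the shared core, and in this assay the exchange lowers inhibition against both carbonyl-linked groups, with a number 25.2 percentage points lower from compound 2 to compound 3 (beyond the scatter) and a number 44.7 percentage points lower from compound 1 to compound 3 (beyond the scatter) on the same core. In the first of these steps, the leaving and entering groups have the same count of heavy atoms and each carries one six-membered aromatic ring, so those shared counts do not keep the number up at this position. Nothing available explains why the sulfonyl compound gives the lowest number of the three.

For the compounds shown here, only one sulfonyl group appears here, so it remains open whether the lower number goes with the sulfonyl link itself or with the 4-methylphenyl group on it. A sulfonyl bearing a short alkyl chain or an amine instead of that ring would help separate the two.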